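The source may report more compounds than this note shows. Statements on the series, on what has been measured and on what is new or still open speak of the compounds shown alone.

Compound 1 `COc1ccc(C#Cc2ccc(C(=O)N3CCC(CO)C3)cc2)cc1` carries a 3-(hydroxymethyl)pyrrolidin-1-yl group on a carbonyl carbon whose other neighbour is an aromatic carbon. In a functional assay on HEK293 cells for negative allosteric modulation of metabotropic glutamate receptor 2 (Rattus norvegicus), read by calcium flux, with a stated time of 2.5 min (on this read-out higher numbers stand for weaker inhibition and lower numbers for stronger inhibition), compound 1 gives > 30000 nM, which is a limit of the assay rather than a measured number. Going by the values given here, compound 2 `COc1ccc(C#Cc2ccc(C(=O)N3CCC[C@@H](O)C3)cc2F)cc1` is the only other compound tested so far and is a close relative of compound 1. In this assay compound 2 gives > 30000 nM, again a limit. Among the compounds with values here, both results therefore sit at the same limit (the limit of > 30000 nM in this assay, at which 2 of the 2 values shown sit), so no step between measured compounds can be sized, and compound 1 stands at the limit alongside its one companion. Compound 3 `COc1ccc(C#Cc2ccc(C(=O)N3CCCC(C)(O)C3)cc2)cc1` has not yet been measured. It differs from compound 1 by 3-hydroxy-3-methylpiperidin-1-yl in place of 3-(hydroxymethyl)pyrrolidin-1-yl on a carbonyl carbon. Within the data shown here, with both measured compounds at the limit there is no measured step to lean on. The step from compound 1 to compound 3 is expected to be none beyond the scatter, giving a number no higher from compound 1 to compound 3 (the limit leaves the size open). For compound 3 the estimate in this assay is 30000 nM, with a range from 10000 nM to 100000 nM, and it is expected that most likely only a limit will again be reported.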

Compound 3, half-maximal inhibitory concentration: > 30000 nM
Compound 3: only a limit was reported; the forecaster's own chance of this, stated with the estimate: 85%; the middle value sits exactly at the limit.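

Going by these compounds alone, compound 1 and compound 3 each give only a limit, so no step between them can be read in this assay: the limit of > 30000 nM in this assay, at which 3 of the 3 values shown sit. The compounds shown leave open how strongly any of them inhibits, and whether 3-hydroxy-3-methylpiperidin-1-yl in place of 3-(hydroxymethyl)pyrrolidin-1-yl on a carbonyl carbon changes the read-out at all.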